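The source may hold more compounds than are shown below. What is called first, only, known or untested is meant among the compounds shown, and "the series" means these compounds.

Of the compounds shown here, three have been measured in an assay on cell membranes for displacement of a labelled ligand from corticotropin-releasing factor receptor 1 (Rattus norvegicus); on this read-out lower numbers stand for stronger inhibition and higher numbers for weaker inhibition. Compound 1 `CCC(CC)Nc1nc(C)nc2c(-c3ccc(OC)cc3)c(C)nn12` gives 3.8 nM. Compound 2 `COCC(COC)Nc1nc(C)nc2c(-c3ccc(OC)cc3C)c(C)nn12` gives 9.7 nM, and compound 3 `COc1cc(C)c(-c2c(C)nn3c(NC4CCC4)nc(C)nc23)c(OC)c1` gives 17.4 nM. Among these three numbers compound 2 holds the second highest; compound 3 sits nearest to it, within the usual scatter, while compound 1 lies furthest from it with a lower number, a gap beyond the scatter.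

The untested compound 4 `COc1ccc(-c2c(C)nn3c(N4CCCC4)nc(C)nc23)c(C)c1` differs from compound 2 in one place: pyrrolidin-1-yl in place of (2-methoxy-1-(methoxymethyl)ethyl)amino on an aromatic carbon. Among the compounds with values here, the group that leaves carries one hydrogen-bond donor and the group that enters carries none; every measured compound here keeps such a donor on its amino group, so no measured pair shows what its removal does. Within the data shown here, with no step of this kind on record, the account expects the number for compound 4 to rise in this assay, by a step of modest size that may reach beyond the scatter, the expected step being a 3.1-fold higher number from compound 2 to compound 4 (0.49 log units; beyond the scatter). Compound 4 is therefore estimated at 30 nM in this assay, with a range from 6 nM to 150 nM.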

Compound 4, half-maximal inhibitory concentration: 80.7 nM
Estimate against measurement, compound 4: 2.7-fold (0.43 log units) below, within the range that was stated.
By their numbers in this assay, from the lowest: compound 1; then compounds 2 and 3 (each within the scatter of the next); then compound 4.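

In this assay, within the data shown here, pyrrolidin-1-yl in place of (2-methoxy-1-(methoxymethyl)ethyl)amino on this aromatic carbon, between two ring nitrogen atoms, gives an 8.3-fold higher number from compound 2 to compound 4 (0.92 log units; beyond the scatter), the first step on record at this position and one that lies beyond the scatter. The position is therefore not indifferent to the group it carries, at least for this pair, but the change is a composite one: the hydrogen-bond donor and the open chain with its oxygen atoms leave together, and a five-membered ring enters. Nothing at hand assigns the rise to any one of these differences.

The compounds shown leave open whether a bis(2-methoxyethyl)amino group, which keeps the two ether oxygens on an amino nitrogen that bears no hydrogen, would follow compound 2 or compound 4, and a cyclopentylamino group would pose the same question from the other side, with a ring and the amino hydrogen together. Going by these compounds, whether a step of this size would recur on the other aryl groups seen also remains open, since this single pair shares one aryl group.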